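Solubility notes: cyclopentyl to trifluoromethylcyclohexyl on the shared core

This account rests on a few compounds, and the source may have more. Where it says the series, first, only, none or still open, it means among the compounds named here.

Measured so far:
compound 1 `FC(F)(F)c1cccc(-c2nc3cnc(Nc4ccc(-c5nnn[nH]5)cn4)cc3[nH]2)c1`: < 5000 nM
compound 2 `FC(F)(F)c1ccc(Nc2cc3[nH]c(C4CCCC4)nc3cn2)nc1`: 85000 nM

In a physicochemical assay for solubility, using the shake flask method, in simulated intestinal fluid, measured as kinetic solubility, with a stated time of 20 h, at pH 6.5 (a lower number here means a less soluble compound, a higher number a more soluble compound), compound 2 gives 85000 nM. Among the compounds with values here, this is the only number in hand for this assay. For compound 1 the reading is a limit and not a number, (the limit of < 5000 nM in this assay, at which 1 of the 2 values shown sits), so the two measured compounds cannot be set against each other beyond noting that compound 2 has a value where compound 1 does not.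

Compound 3 `FC(F)(F)c1ccc(Nc2cc3[nH]c([C@H]4CC[C@H](C(F)(F)F)CC4)nc3cn2)nc1` is not yet measured. It differs from compound 2 in one place: 4-(trifluoromethyl)cyclohexyl in place of cyclopentyl on an aromatic carbon. Within the data shown here, no measured step in this assay connects two compounds that differ in one place, so the size of the change has to be guessed. The entering group is larger than the leaving one and carries a trifluoromethyl; the expectation is a step downward in this assay, clearly beyond the scatter, while staying short of the limit at which compound 1 sits.

The step from compound 2 to compound 3 is expected to be a 5.7-fold lower number from compound 2 to compound 3 (0.75 log units; beyond the scatter). For compound 3 the estimate in this assay is 15000 nM, with a range from 4000 nM to 50000 nM.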

Compound 3, solubility: 104000 nM
Compound 3: the middle estimate sits 6.9-fold (0.84 log units) below what was measured; measured number outside the range, above it.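

In this assay, this position, an aromatic carbon between two ring nitrogen atoms, now has a measured single-place change: the step is a 1.2-fold higher number from compound 2 to compound 3 (0.09 log units; within the scatter), so the exchange of cyclopentyl for 4-(trifluoromethyl)cyclohexyl gives no distinguishable difference in the read-out. The entering group has 10 heavy atoms, including 3 fluorine, and 2 defined stereocentres, against 5 heavy atoms in the leaving group, so this one pair shows that a change of that extent at this place can leave the solubility reading within the scatter. Nothing measured in this series accounts for this outcome.

This single pair does not show whether the same holds in this assay for other groups at this position, such as a cyclohexyl ring carrying an amine or a carboxylic acid in place of the trifluoromethyl. On these data alone, the other arrangement of the two stereocentres, and the same exchange on a core with a different group on the far side of the amine nitrogen, also remain open.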